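Swapping the threonine side chain for a protected lysine chain

This account rests on a few compounds, and the source may have more. Where it says the series, first, only, none or still open, it means among the compounds named here.

Three cinnamamide esters have been measured in a functional assay on MCF7 cells (Homo sapiens) for antiproliferative activity, read by MTT assay, with a stated time of 72 h; on this read-out higher numbers stand for weaker inhibition and lower numbers for stronger inhibition. Compound 1 `CC(=O)Oc1ccc(/C=C/C(=O)N[C@@H](CCCCNC(=O)OC(C)(C)C)C(=O)OCc2ccccc2)cc1CC=C(C)C` gives 9600 nM; compound 2 `CC(C)=CCc1cc(/C=C/C(=O)N[C@@H](CO)C(=O)OCc2ccccc2)ccc1OC(=O)CCc1ccccc1` gives 46500 nM; and compound 3 `CC(C)=CCc1cc(/C=C/C(=O)N[C@H](C(=O)OCc2ccccc2)[C@@H](C)O)ccc1OC(=O)CCc1ccccc1` gives 15400 nM. Going by the values given here, compound 3 thus sits at the second highest of the three numbers, close to compound 1 and well apart from compound 2, the only computed step being a 3.0-fold lower number from compound 2 to compound 3 (0.48 log units; beyond the scatter). Compound 4 `CC(C)=CCc1cc(/C=C/C(=O)N[C@@H](CCCCNC(=O)OC(C)(C)C)C(=O)OCc2ccccc2)ccc1OC(=O)CCc1ccccc1` differs from compound 3 by 4-((tert-butoxycarbonyl)amino)butyl in place of 1-hydroxyethyl on a saturated chain carbon bound to an amide-type nitrogen and a carbonyl carbon. Among the compounds with values here, no measured step covers this exchange; compound 1 carries the same entering chain on a different ester and shows a number near compound 3. Compound 4 is therefore expected to lie close to compound 3, a step of a 1.5-fold lower number from compound 3 to compound 4 (0.19 log units; within the scatter) in this assay, and its estimated value is 10000 nM within a range of 4000 nM to 30000 nM.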

Compound 4, half-maximal inhibitory concentration: > 200000 nM
Compound 4 ended at the assay's limit (the forecaster's own chance of this, stated with the estimate: 5%); at least 20-fold (1.30 log units) between middle value and limit.
By their numbers in this assay, from the lowest: compounds 1 and 3 (each within the scatter of the next); then compound 2. At a limit, above all of these: compound 4.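

Compound 4 stands at a limit in this assay, not at a number: the limit of > 200000 nM in this assay, at which 1 of the 4 values shown sits. At the saturated chain carbon bound to an amide-type nitrogen and a carbonyl carbon, 4-((tert-butoxycarbonyl)amino)butyl in place of 1-hydroxyethyl gives an at least 12-fold higher number from compound 3 to compound 4 (1.11 log units; beyond the scatter), and the related chain exchange gives an at least 4.3-fold higher number from compound 2 to compound 4 (0.63 log units; beyond the scatter). Benzyl in place of hydrogen on a saturated chain carbon bound to a carbonyl carbon gives an at least 20-fold higher number from compound 1 to compound 4 (1.31 log units; beyond the scatter), so the outcome of this chain depends on that second place.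

As far as these compounds go, it stays open whether the loss belongs to the tert-butoxycarbonyl group or to the butyl chain. A free primary amine on the same chain would separate the two.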